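Removing a Methoxy Group in a Paw Edema Series

The source may report more compounds than this note shows. Statements on the series, on what has been measured and on what is new or still open speak of the compounds shown alone.

The study compares three measured compounds and one that awaits measurement. Compound 1, `COc1ccc(Cl)c(-c2nnc3sc(Cc4c[nH]c5ccc(OC)cc45)nn23)c1`, and compound 3, `COc1ccc(Cl)c(-c2nnc3sc(Cc4c[nH]c5ccccc45)nn23)c1`, share one core; compound 2, `COc1ccc2[nH]cc(Cc3nn4c(Cc5ccc(OC)c(OC)c5)nnc4s3)c2c1`, and compound 4, `COc1ccc(Cc2nnc3sc(Cc4c[nH]c5ccccc45)nn23)cc1OC`, share another. The difference between the two cores is not broken down here.

In a functional assay on the whole organism (strain Wistar Albino) for inhibition, with Rattus norvegicus as the target, read by paw edema, with a stated time of 1 h, at a dose of 20 mg/kg (a lower number here means less inhibition, a higher number more inhibition at the dose given (going by the name of the read-out)), compound 1 gives 6.1%. In this assay compound 3 gives 8.8%, and compound 2 gives 4.11%. Each of these three numbers lies within the usual scatter of the other two, so no order among the measured compounds can be read from them.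

Compound 3 differs from compound 1 in one place: hydrogen in place of methoxy on an aromatic carbon. That change made a step of a number 2.7 percentage points higher from compound 1 to compound 3 (within the scatter). Compound 4 differs from compound 2 by hydrogen in place of methoxy on an aromatic carbon, which is the same change at a place described in the same words, now on the core shared by compound 2 and compound 4. Among the compounds shown this change occurs twice in all.

The corresponding step is expected to be small, a number 2.9 percentage points higher from compound 2 to compound 4 (within the scatter), because the earlier step of a number 2.7 percentage points higher from compound 1 to compound 3 (within the scatter) stayed within the scatter. Compound 4 is therefore estimated to give 7% in this assay, with an expected range from 2% to 14%.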

Compound 4, a percentage reported as inhibition, in the whole organism at one dose (the size of the read-out at that dose, not a potency): 16.1%
Beside the measured number, compound 4's estimate is 9.1 percentage points below it; measured number above the stated range.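

In this assay, hydrogen in place of methoxy on an aromatic carbon made a step of a number 12 percentage points higher from compound 2 to compound 4 (beyond the scatter), so on the core shared by compound 2 and compound 4 the change produced a rise that stands clear of the usual scatter. Set beside the same change on the core shared by compound 1 and compound 3, the two steps cannot be told apart: the same change on two cores in this assay, a number 2.7 percentage points higher (within the scatter) from compound 1 to compound 3 and a number 12 percentage points higher (beyond the scatter) from compound 2 to compound 4, 9.3 percentage points apart, within the scatter of two such steps This shows that nothing measured here requires the change to behave differently on the two cores, but it does not show that the change carries over with the same size, as the series offers only two such pairs and only one of the two steps lies beyond the scatter.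

The compounds shown have only methoxy or hydrogen at this place, so it remains open how an amine, a carboxylic acid or a longer chain there would compare in this read-out. Also open, going by these compounds, is whether either step would hold at another dose or time, as every number here comes from a single dose and a single stated time.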